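Swapping a sulfonic acid for an acrylic acid

The source may report more compounds than this note shows. Statements on the series, on what has been measured and on what is new or still open speak of the compounds shown alone.

Compound 1 `CC(C)c1ccc2c(CCCCNS(=O)(=O)c3ccccc3)cc(S(=O)(=O)O)c-2cc1` is the reference point. In a functional assay (plasma) for inhibition, with Oryctolagus cuniculus as the target (a higher number here means a weaker inhibitor, a lower number a stronger inhibitor), compound 1 gives > 100000 nM, which is a limit of the assay rather than a number, as noted by the limit of > 100000 nM in this assay, at which 1 of the 2 values shown sits. Its companion compound 2 `COc1ccc(S(=O)(=O)NCCCCc2cc(S(=O)(=O)O)c3ccc(C(C)C)ccc2-3)cc1` carries a methoxy in place of hydrogen on an aromatic carbon; in this assay compound 2 gives 64000 nM. Among the measured compounds shown here, the only measured step, an at least 1.5-fold lower number from compound 1 to compound 2 (0.19 log units; that floor lies within the scatter), starts from that limit and cannot be read as a real change.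

Compound 3 `CC(C)c1ccc2c(/C=C/C(=O)O)cc(CCCCNS(=O)(=O)c3ccccc3)c-2cc1` differs from compound 1 by 2-carboxyethenyl in place of sulfo on an aromatic carbon. For the measured compounds named here, no measured step touches this change: the one step on record concerns a methoxy, not the acidic group, so the data say nothing about how far, or in which direction, this assay should move. The limit for compound 1, > 100000 nM, leaves the starting point itself open. Compound 3 is therefore expected to remain a weak inhibitor, with a step of an at least 1.4-fold lower number from compound 1 to compound 3 (0.15 log units; that floor lies within the scatter) expected. For compound 3 the estimated value in this assay is 70000 nM, within an expected range from 20000 nM to 250000 nM.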

Compound 3, half-maximal inhibitory concentration: > 100000 nM
Compound 3 gave a limit, no number; the forecaster's own chance of this, stated with the estimate: 45%; middle value at least 1.4-fold (0.15 log units) away from the limit.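

In this assay compound 3 gives > 100000 nM, which is a limit of the assay and not a number. Compound 1 stands at a limit as well, so no step can be read from compound 1 to compound 3: the limit of > 100000 nM in this assay, at which 2 of the 3 values shown sit. The compounds shown leave open whether 2-carboxyethenyl in place of sulfo moves the result in this assay at all, and in which direction.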